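This account rests on a few compounds, and the source may have more. Where it says the series, first, only, none or still open, it means among the compounds named here.

Of the compounds shown here, two have so far been measured in an assay on cells for displacement of a labelled ligand from D(1B) dopamine receptor (Homo sapiens), read by scintillation counting, with a stated time of 90 min; on this read-out lower numbers stand for stronger inhibition and higher numbers for weaker inhibition. Compound 1 `Cc1ncc2nccn2c1-c1ccc(Oc2nccc3occc23)cc1C(F)(F)F` gives 82 nM in this assay, and compound 2 `FC(F)(F)c1cc(Oc2nccc3occc23)ccc1-c1cccc2nccn12` gives 47 nM. Going by the values given here, compound 2 stands with the lower of the two numbers, its only neighbour being compound 1 at a difference that stays within the scatter, so the two cannot be ranked against each other. Among the compounds with values here, the one measured step, a 1.7-fold lower number from compound 1 to compound 2 (0.24 log units; within the scatter), exchanges a fused group on an aromatic carbon and leaves the rest of the molecule untouched.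

Compound 3 `FC(F)(F)c1cc(Oc2nccc3ccsc23)ccc1-c1cccc2nccn12` carries a different change: a group of 9 heavy atoms (7 carbon, 1 nitrogen, 1 sulfur; one five-membered aromatic ring with 1 hetero atom, one six-membered aromatic ring with 1 hetero atom) in place of a group of 9 heavy atoms (7 carbon, 1 nitrogen, 1 oxygen; one five-membered aromatic ring with 1 hetero atom, one six-membered aromatic ring with 1 hetero atom), on an oxygen on an aromatic ring. Within the data shown here, no measured step touches this part of the structure, so the step from compound 1 to compound 2 offers no direct guide, and the expectation rests on the exchange being a like-for-like swap of two fused rings with the same counts of atoms and acceptors. A step no larger than the scatter is therefore expected, in no set direction, estimated as a 1.1-fold higher number from compound 2 to compound 3 (0.03 log units; within the scatter). Compound 3 is expected to give about 50 nM in this assay, most likely between 15 nM and 170 nM.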

Compound 3, inhibition constant: 27 nM
The estimate for compound 3 lay 1.9-fold (0.27 log units) above the measured number; measured number inside the range.
By their numbers in this assay, from the lowest: compounds 3, 2 and 1 (each within the scatter of the next, the first and the last beyond it).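

In this assay, replacing the oxygen-containing fused group with its sulfur-containing counterpart, on an oxygen on an aromatic ring, gives a 1.7-fold lower number from compound 2 to compound 3 (0.24 log units; within the scatter). Going by these compounds alone, this is the first measured change at this position, which the earlier step left untouched, and it shows that this one exchange of oxygen for sulfur in the five-membered aromatic ring, with the counts of heavy atoms and hydrogen-bond acceptors unchanged, does not carry the number beyond the scatter. Nothing available explains the size or direction of this step.

The compounds shown leave open how the number would respond to a group of a different kind at this position, such as a plain phenyl ring, a piperidine or a chain bearing a carboxylic acid, and so whether any exchange there can move it beyond the scatter. They also leave open whether the trifluoromethyl group, common to all three compounds, could give way to a nitrile or a chlorine atom without a step beyond the scatter.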